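The source may hold more compounds than are shown below. What is called first, only, known or untested is meant among the compounds shown, and "the series" means these compounds.

Measured so far:
Compound 1 `COC(=O)CCNC(=O)[C@@H]1O[P@](=O)(OCOC(=O)c2scnc2C)OCC1(C)C` — in an ADME assay on blood (Homo sapiens) for pharmacokinetics (on this read-out lower numbers stand for a shorter-lived compound and higher numbers for a longer-lived compound), compound 1 gives < 0.16 h, a limit of the assay rather than a number.
Compound 2 `COC(=O)CCNC(=O)[C@@H]1O[P@](=O)(OCOC(=O)c2cc(C)nn2C)OCC1(C)C` — in this assay compound 2 gives < 0.16 h, again a limit of the assay.

Compound 2 thus stands at the limit of this assay, and nothing is known of how far beyond it the true value lies. Among the measured compounds shown here, the one step measured, a step that the two limits leave unreadable from compound 1 to compound 2, cannot be read, since both of its ends are limits; the record shows only (the limit of < 0.16 h in this assay, at which 2 of the 2 values shown sit).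

Compound 3 `COC(=O)CCNC(=O)[C@@H]1O[P@](=O)(OCOC(=O)c2ccns2)OCC1(C)C` differs from compound 2 by 1,2-thiazol-5-yl in place of 1,3-dimethyl-1H-pyrazol-5-yl on a carbonyl carbon. For the measured compounds named here, the only measured step that bears on a change of the ring on the carbonyl carbon is the one from compound 1 to compound 2, and its size is not readable. No direction can be drawn from it. The expectation for compound 3 in this assay is therefore that it stays at the limit, estimated at 0.1 h with a range of 0.04 h to 0.3 h. The step this estimate means is expected to be a step that the limit leaves unreadable from compound 2 to compound 3.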

Compound 3, half-life: < 0.16 h
Compound 3 was reported as a limit; the forecaster's own chance of this, stated with the estimate: 85%; the middle value lies beyond the limit too.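

The steps among compound 1, compound 2 and compound 3 cannot be read, since all three stand at a limit in this assay: the limit of < 0.16 h in this assay, at which 3 of the 3 values shown sit. Still open, on these data alone, is how far each true value lies beyond that limit, and whether changing the ring on the carbonyl carbon shifts it.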